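The source may hold more compounds than are shown below. What is called first, only, known or untested is meant among the compounds shown, and "the series" means these compounds.

Series notes. Compound 3 `CC(C)c1onc(-c2c(Cl)cccc2Cl)c1COc1ccc(-c2nc3ccc(C(=O)O)cc3n2CC2CCCCC2)cc1` gives the lowest number of the three measured in an assay on HEK-293T cells for antagonist activity at vitamin D3 receptor (Homo sapiens), read by a luciferase reporter, with a stated time of 24 h (a higher number here means a weaker inhibitor, a lower number a stronger inhibitor), at 346 nM. Compound 1 `CC(C)c1onc(-c2c(Cl)cccc2Cl)c1COc1ccc(-c2nc3ccc(C(=O)O)cc3n2CC(C)(C)C)cc1` gives 861 nM and compound 2 `CCn1c(-c2ccc(OCc3c(-c4c(Cl)cccc4Cl)noc3C(C)C)cc2)nc2ccc(C(=O)O)cc21` gives 5760 nM in this assay; the steps of a 2.5-fold lower number from compound 1 to compound 3 (0.40 log units; beyond the scatter) and a 17-fold lower number from compound 2 to compound 3 (1.22 log units; beyond the scatter) both place compound 3 at the low end, beyond the scatter in each case.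

Compound 4 `CC(C)c1onc(-c2c(Cl)cccc2Cl)c1COc1ccc(-c2nc3ccc(C(=O)O)cc3n2C2CCCCC2)cc1` differs from compound 3 by cyclohexyl in place of cyclohexylmethyl on an aromatic nitrogen. The measured steps that bear on this position all alter the group bound to the aromatic nitrogen: a 6.7-fold higher number from compound 1 to compound 2 (0.83 log units; beyond the scatter), a 2.5-fold lower number from compound 1 to compound 3 (0.40 log units; beyond the scatter) and a 17-fold lower number from compound 2 to compound 3 (1.22 log units; beyond the scatter). In each the number fell as the group on the nitrogen grew. Going by the values given here, none of them removes the saturated chain carbon bound to the aromatic nitrogen, so the change to compound 4 has no direct precedent here; it makes the group on the nitrogen smaller, and a modest rise in this assay is therefore expected rather than a fall. For compound 4 the expected step is a 1.7-fold higher number from compound 3 to compound 4 (0.24 log units; within the scatter). Compound 4 is accordingly estimated at 600 nM, with a range of 200 nM to 2000 nM.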

Compound 4, half-maximal inhibitory concentration: 1450 nM
Estimate against measurement, compound 4: 2.4-fold (0.38 log units) below; measured number inside the range.
By their numbers in this assay, from the lowest: compound 3; then compounds 1 and 4 (each within the scatter of the next); then compound 2.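

In this assay, the saturated chain carbon on the aromatic nitrogen matters in its own right: with the six-membered ring kept, cyclohexyl in place of cyclohexylmethyl gives a clear loss (a 4.2-fold higher number from compound 3 to compound 4 (0.62 log units; beyond the scatter)). Cyclohexyl directly on the nitrogen still outperforms the ethyl group of compound 2 (a 4.0-fold lower number from compound 2 to compound 4 (0.60 log units; beyond the scatter)), while it cannot be separated from the neopentyl group of compound 1 (a 1.7-fold higher number from compound 1 to compound 4 (0.23 log units; within the scatter)). Nothing available explains why that one carbon counts.

As far as these compounds go, it remains open whether cyclohexylethyl, with a longer chain to the ring, would lower the number further than cyclohexylmethyl. Also open, from the compounds shown here alone, is whether benzyl, with a phenyl ring in place of the cyclohexyl ring, would keep the level of compound 3.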